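The compounds below may be only part of what the source reports. "The series", "measured", "known", "first", "only" and "open" are said of these compounds alone.

Working notes on the series.

Within the data shown here, the three measured members share one core, carrying an ethyl ester and the hydrazino-linked imide, and differ only in the group on the aromatic carbon between the two ring nitrogen atoms. Compound 1 `CCOC(=O)c1cnc(CC)nc1NN1C(=O)C=C(C)C1=O` carries ethyl there; in a functional assay on Jurkat cells for inhibition of nuclear factor NF-kappa-B complex (Homo sapiens) (on this read-out higher numbers stand for weaker inhibition and lower numbers for stronger inhibition), compound 1 gives 10000 nM. Compound 2 `CCOC(=O)c1cnc(-c2ccncc2)nc1NN1C(=O)C=C(C)C1=O` carries pyridin-4-yl and gives 6000 nM in this assay. Compound 3 `CCOC(=O)c1cnc(-c2cnc3ccccc3c2)nc1NN1C(=O)C=C(C)C1=O` carries quinolin-3-yl and gives 6000 nM in this assay. The steps of a 1.7-fold lower number from compound 1 to compound 2 (0.22 log units; within the scatter) and a 1.7-fold lower number from compound 1 to compound 3 (0.22 log units; within the scatter) are both within the scatter, and no change at the digits printed from compound 2 to compound 3 (within the scatter) shows no movement. Compound 3 therefore stands level with compound 2 at the digits given, both at the lowest of the three numbers, with compound 1 nearest to them; none of the three is separable from the others.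

Compound 4 `CCOC(=O)c1cnc(-c2ccc(OC)cc2)nc1NN1C(=O)C=C(C)C1=O` carries 4-methoxyphenyl in place of quinolin-3-yl on an aromatic carbon. Among the measured compounds shown here, the steps that bear on this change are the three exchanges of the same group already seen, none of which moved this assay beyond the scatter. No change beyond the scatter is expected for a 1.2-fold higher number from compound 3 to compound 4 (0.07 log units; within the scatter). For compound 4 the estimate in this assay is 7000 nM, with a range from 3000 nM to 15000 nM.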

Compound 4, half-maximal inhibitory concentration: 900 nM
The estimate for compound 4 lay 7.8-fold (0.89 log units) above the measured number, outside the stated range (below it).
By their numbers in this assay, from the lowest: compound 4; then compounds 2, 3 and 1 (each within the scatter of the next).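

Compound 4 shows that the group at this carbon can move this assay beyond the scatter: 4-methoxyphenyl gives a 6.7-fold lower number from compound 3 to compound 4 (0.82 log units; beyond the scatter) when it replaces quinolin-3-yl and a 6.7-fold lower number from compound 2 to compound 4 (0.82 log units; beyond the scatter) when it replaces pyridin-4-yl, whereas the exchanges among ethyl, pyridin-4-yl and quinolin-3-yl moved nothing beyond the scatter. Against ethyl the change gives an 11-fold lower number from compound 1 to compound 4 (1.05 log units; beyond the scatter) and is the only step of the series printed as large, so compound 4 alone separates from all the others and holds the lowest number, while the aromatic groups of compounds 2 and 3 do not separate from ethyl. No measurement at hand accounts for this gain.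

The compounds shown do not separate the methoxy group from the phenyl ring that carries it, and a plain phenyl, a 4-chlorophenyl or a 4-hydroxyphenyl group at this carbon would bear on that question. On these data alone, the ethoxycarbonyl group stays the same in all four compounds, so it also remains open whether the gain from 4-methoxyphenyl would hold with a carboxylic acid or an amide in its place.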